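Three Limits and a Fluoro-Methoxyphenyl Newcomer

The source may report more compounds than this note shows. Statements on the series, on what has been measured and on what is new or still open speak of the compounds shown alone.

Measured compounds:
- compound 1, `CCOC(=O)CCCCCOc1cccc(CN(C(=O)c2ccc(-c3cccc(OCC(C)C)c3)cc2)C(C)C)c1`: > 26000 nM
- compound 2, `CCOC(=O)CCCCCOc1cccc(CN(C(=O)c2ccc(-c3cccc(OC(C)C)c3)cc2)C(C)C)c1`: > 26000 nM
- compound 3, `CCOC(=O)CCCCCOc1cccc(CN(C(=O)c2ccc(-c3ccco3)cc2)C(C)C)c1`: > 26000 nM

In an ADME assay on Raji cells (Homo sapiens) for cytotoxicity, read by CellTiter-Glo and resazurin assay, with a stated time of 72 h (a lower number here means that less compound is needed, a higher number that more compound is needed for the effect), compound 1 gives only a limit, > 26000 nM. Compound 2 likewise gives only a limit in this assay, > 26000 nM. Compound 3 also stands at a limit in this assay, > 26000 nM, so no number is known for it; this is where the piece starts. The three measured steps, a step that the two limits leave unreadable from compound 1 to compound 2, a step that the two limits leave unreadable from compound 1 to compound 3 and a step that the two limits leave unreadable from compound 2 to compound 3, are all unreadable, since both ends sit at the same limit, a point summed up by the limit of > 26000 nM in this assay, at which 3 of the 3 values shown sit.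

Compound 4, `CCOC(=O)CCCCCOc1cccc(CN(C(=O)c2ccc(-c3cc(F)cc(OC)c3)cc2)C(C)C)c1`, differs from compound 3 in one place: 3-fluoro-5-methoxyphenyl in place of furan-2-yl on an aromatic carbon. Among the measured compounds shown here, none of the measured steps gives a readable size, so no step direction can be taken from them. What they do show is that changes at this aromatic carbon, whether an isobutoxy or isopropoxy phenyl or a furan, all leave this assay at its limit. The expectation is therefore a step that the limit leaves unreadable from compound 3 to compound 4 that stays within the scatter. Compound 4 is expected to give about 30000 nM in this assay, with a range from 15000 nM to 60000 nM, most likely reported again as a limit.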

Compound 4, half-maximal effective concentration: > 26000 nM
Compound 4: a limit, no number; the forecaster's own chance of this, stated with the estimate: 85%; the middle value lies beyond the limit too.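

In this assay compound 4 gives > 26000 nM as its result, which is a limit and not a number. Its steps to compound 1, compound 2 and compound 3 cannot be read, since all four compounds end at the same limit: the limit of > 26000 nM in this assay, at which 4 of the 4 values shown sit.

How far beyond that limit each of these compounds truly lies stays open, so they cannot be ranked.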